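Thiophene Amide Chain Replaces the Geranyl Ether in Compound 3

The compounds below may be only part of what the source reports. "The series", "measured", "known", "first", "only" and "open" are said of these compounds alone.

Compound 1 `CCOc1cc(=O)n(CCCO)c2c1CC(C/C=C(\C)CCC=C(C)C)C(C)(C)C2`: 0.8%
Compound 2 `CC(C)=CCC/C(C)=C/COc1cc(=O)n(CCCO)c2c1CC(C/C=C(\C)CCC=C(C)C)C(C)(C)C2`: 3.1%

Among the compounds with values here, in a functional assay on PANC-1 cells (Homo sapiens) for inhibition, read by MTT assay, with a stated time of 24 h, tested at 10 uM (on this read-out higher numbers stand for more inhibition at the one concentration tested (going by the name of the read-out) and lower numbers for less inhibition), compound 2 gives 3.1%, and the only other number comes from compound 1, the gap being a number 2.3 percentage points higher from compound 1 to compound 2 (within the scatter). Compound 3 `CC(C)=CCC/C(C)=C/CC1Cc2c(OCCCNC(=O)c3cccs3)cc(=O)n(CCCO)c2CC1(C)C` differs from compound 2 by 2-(((thiophen-2-yl)carbonyl)amino)ethyl in place of 2,6-dimethylhepta-1,5-dien-1-yl on a saturated chain carbon bound to an oxygen on an aromatic ring. Within the data shown here, the single measured step at that same place, a number 2.3 percentage points higher from compound 1 to compound 2 (within the scatter), left the read-out inside the scatter, and nothing else measured bears on this change. Compound 3 is therefore expected to stay close to compound 2, with an expected step of a number 0.1 percentage points lower from compound 2 to compound 3 (within the scatter). The estimated value of compound 3 in this assay is 3%, within a range from 0% to 12%.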

Compound 3, a percentage reported as inhibition, at one concentration (the size of the read-out at that concentration, not a potency): 11.5%
The estimate for compound 3 lay 8.5 percentage points below the measured number; the measured number falls inside the stated range.
By their numbers in this assay, from the lowest: compounds 1, 2 and 3 (each within the scatter of the next, the first and the last beyond it).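

In this assay, within the data shown here, the amide-bearing chain on this oxygen gives the first step to pass the scatter, a number 10.7 percentage points higher from compound 1 to compound 3 (beyond the scatter), and that step is modest. Against the 3,7-dimethylocta-2,6-dien-1-yl chain the same chain stays inside the scatter, a number 8.4 percentage points higher from compound 2 to compound 3 (within the scatter), so the position accepts a thiophene amide without any clear gain over that chain. Nothing available explains the step.

From the compounds shown here alone, whether the amide or the thiophene carries the step remains open. So does what a terminal amine, a carboxylic acid or a phenyl ring in place of thiophene would do on this chain.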